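Piperazine aryl variation and the next halogenated phenyl

The source may report more compounds than this note shows. Statements on the series, on what has been measured and on what is new or still open speak of the compounds shown alone.

Of the compounds shown here, three of the shared core have numbers so far in a functional assay on CHO cells with adenosine receptor A1 (Homo sapiens) as the target, read by cAMP accumulation and immunoassay, with a stated time of 6 min, tested at 1 uM; on this read-out lower numbers stand for a stronger effect and higher numbers for a weaker effect at the one concentration tested. Compound 1 `Nc1scc(CN2CCN(c3ccc(F)cc3Cl)CC2)c1C(=O)c1ccc(Cl)cc1` gives -39%, compound 2 `Nc1scc(CN2CCN(c3ccc([N+](=O)[O-])cc3)CC2)c1C(=O)c1ccc(Cl)cc1` gives -8.3%, and compound 3 `Nc1scc(CN2CCN(c3cccc4ccccc34)CC2)c1C(=O)c1ccc(Cl)cc1` gives 2.9%. Compound 2 stands second highest of the three: the nearest number is that of compound 3, with a number 11.2 percentage points higher from compound 2 to compound 3 (beyond the scatter), and the furthest is that of compound 1, with a number 30.7 percentage points higher from compound 1 to compound 2 (beyond the scatter).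

Compound 4 `Nc1scc(CN2CCN(c3cccc(F)c3F)CC2)c1C(=O)c1ccc(Cl)cc1` differs from compound 2 by 2,3-difluorophenyl in place of 4-nitrophenyl on an amine nitrogen in a ring.

Going by the values given here, of the measured steps, the one bearing on this change is the large one from a halogenated phenyl to the nitrophenyl, a number 30.7 percentage points higher from compound 1 to compound 2 (beyond the scatter), which compound 4 partly reverses, though with a different halogen pattern than compound 1; the step of a number 41.9 percentage points higher from compound 1 to compound 3 (beyond the scatter) shows that the nitrophenyl is not alone in standing far above compound 1. A step downward in this assay beyond the scatter is therefore expected, but smaller than the full return to compound 1. For compound 4 the expected value is -25%, within -45% to -5%, which means an expected step of a number 16.7 percentage points lower from compound 2 to compound 4 (beyond the scatter).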

Compound 4, a percentage reported as activity, at one concentration (the size of the read-out at that concentration, not a potency): -66%
The estimate for compound 4 lay 41 percentage points above the measured number, and the stated range ends above it.
By their numbers in this assay, from the lowest: compound 4; then compound 1; then compound 2; then compound 3.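

In this assay, 2,3-difluorophenyl on the amine nitrogen in a ring gives the lowest number of the four compounds, with a number 57.7 percentage points lower from compound 2 to compound 4 (beyond the scatter) and a number 68.9 percentage points lower from compound 3 to compound 4 (beyond the scatter). The earlier compounds shown here did not show that the number could go past that of the 2-chloro-4-fluorophenyl of compound 1, yet here a number 27 percentage points lower from compound 1 to compound 4 (beyond the scatter), so exchanging one halogenated phenyl for another at this position also moves the number beyond the scatter. No measured evidence here accounts for these steps.

Still open, as far as these compounds go, is whether the kind of halogen or its place on the phenyl ring matters more, as compound 1 and compound 4 differ in both. A 2,3-dichlorophenyl or an unsubstituted phenyl at the same position would help to separate these two readings.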